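The source may hold more compounds than are shown below. What is called first, only, known or untested is meant among the compounds shown, and "the series" means these compounds.

Three amides of the shared core have been run in a functional assay on HeLa cells (Homo sapiens) for inhibition, read by MTT assay, with a stated time of 48 h; on this read-out higher numbers stand for weaker inhibition and lower numbers for stronger inhibition. Compound 1 `COc1ccc2c(=O)c(/C=C/C(=O)Nc3ccc(C)cc3)coc2c1` gives 24100 nM. For compound 2 `COc1ccc2c(=O)c(/C=C/C(=O)Nc3ccc(Cl)cc3)coc2c1` the assay returns only a limit, > 100000 nM. For compound 3 `COc1ccc2c(=O)c(/C=C/C(=O)NCc3ccc(F)cc3)coc2c1` the result is likewise a limit, > 100000 nM, so compound 3 stands at the weak end of what is shown, sitting at the limit of > 100000 nM in this assay, at which 2 of the 3 values shown sit. The step of an at least 4.1-fold higher number from compound 1 to compound 2 (0.61 log units; beyond the scatter) and the step of an at least 4.1-fold higher number from compound 1 to compound 3 (0.61 log units; beyond the scatter) both run from a measured number up to that limit; the step that the two limits leave unreadable from compound 2 to compound 3 cannot be read, since both ends are limits.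

Compound 4 `CCOc1ccc(NC(=O)/C=C/c2coc3cc(OC)ccc3c2=O)cc1` is the next amide and differs from compound 3 by 4-ethoxyphenyl in place of 4-fluorobenzyl on an amide-type nitrogen. This change returns from a benzyl to an aryl amide, the reverse of the move in the step of an at least 4.1-fold higher number from compound 1 to compound 3 (0.61 log units; beyond the scatter), and puts an ethoxy where compound 1 carries a methyl and compound 2 a chloro. Compound 1 with the methyl gave 24100 nM. Compound 2 with the chloro sits at the limit > 100000 nM.

On the reversal alone a lower number than compound 3 is expected, but the size is uncertain. Compound 4 is therefore estimated at 40000 nM, within a range from 10000 nM to 150000 nM. This corresponds to an expected at least 2.5-fold lower number from compound 3 to compound 4 (0.39 log units; beyond the scatter), with a fair chance that the assay again reports only a limit.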

Compound 4, half-maximal inhibitory concentration: > 100000 nM
Compound 4: no number, only a limit; the forecaster's own chance of this, stated with the estimate: 40%; middle value at least 2.5-fold (0.39 log units) from the limit.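

Compound 4 shows that a return from 4-fluorobenzyl to an aryl amide on the amide-type nitrogen does not by itself give a readable number in this assay, so the aryl amide alone does not account for the reading of compound 1. Swapping the methyl for an ethoxy gives an at least 4.1-fold higher number from compound 1 to compound 4 (0.61 log units; beyond the scatter), and among the three aryl amides, compounds 1, 2 and 4, only the methyl compound now has a number. The steps from compound 2 and compound 3 to compound 4 cannot be read, and the series stays bunched at one end of the read-out: the limit of > 100000 nM in this assay, at which 3 of the 4 values shown sit.

From the compounds shown here alone, with a single measured number, the order of the chloro, ethoxy and 4-fluorobenzyl compounds remains unknown, and so does how far each lies from compound 1. Also open, going by these compounds, is whether the reading of compound 1 depends on the methyl itself, which an ethyl, an amine or a carboxylic acid at that place on the shared core would help to settle, provided such compounds gave numbers rather than limits.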